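The source may report more compounds than this note shows. Statements on the series, on what has been measured and on what is new or still open speak of the compounds shown alone.

Working notes on the series, all on the shared core and read in a functional assay on HGC-27 cells (Homo sapiens) for antiproliferative activity, read by MTT assay, with stated times of 72 h and 4 h; on this read-out lower numbers stand for stronger inhibition and higher numbers for weaker inhibition. Compound 1 `COc1ncc(-c2cc3c(N4C[C@@H](C)O[C@@H](C)C4)ncnc3s2)cc1NS(=O)(=O)c1ccc(F)cc1F` gives 560 nM, compound 2 `COc1ncc(-c2cc3c(N4CC(OC)C4)ncnc3s2)cc1NS(=O)(=O)c1ccc(F)cc1F` gives 830 nM and compound 3 `COc1ncc(-c2cc3c(N4CC5COCC5C4)ncnc3s2)cc1NS(=O)(=O)c1ccc(F)cc1F` gives 300 nM. Compound 3 stands with compound 1 at the low end of these three numbers, the step between them being a 1.9-fold lower number from compound 1 to compound 3 (0.27 log units; within the scatter). Only the gap to compound 2 clears the scatter, at a 2.8-fold lower number from compound 2 to compound 3 (0.44 log units; beyond the scatter), while a 1.5-fold higher number from compound 1 to compound 2 (0.17 log units; within the scatter) does not.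

Compound 4 `COc1ncc(-c2cc3c(N4CCN(C)C(=O)C4)ncnc3s2)cc1NS(=O)(=O)c1ccc(F)cc1F` changes one group: a group of 8 heavy atoms (5 carbon, 2 nitrogen, 1 oxygen; one six-membered non-aromatic ring with 2 hetero atoms) in place of a group of 8 heavy atoms (6 carbon, 1 nitrogen, 1 oxygen; 2 five-membered non-aromatic rings with 1 hetero atom each), on an aromatic carbon. The entering group is 4-methyl-3-oxopiperazin-1-yl. Within the data shown here, no measured compound carries it, so no measured step covers it directly. The nearest guide is compound 1, which also has one six-membered non-aromatic ring with 2 hetero atoms at this place and gives 560 nM. All three measured steps are small, so a small step is expected here too, towards a higher number and probably not far beyond the scatter. The expected change is a 1.8-fold higher number from compound 3 to compound 4 (0.26 log units; within the scatter). The estimated value for compound 4 is 550 nM, with an expected range of 220 nM to 1400 nM.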

Compound 4, half-maximal inhibitory concentration: 920 nM
The estimate for compound 4 lay 1.7-fold (0.22 log units) below the measured number; the measured number falls inside the stated range.
By their numbers in this assay, from the lowest: compounds 3, 1, 2 and 4 (each within the scatter of the next, the first and the last beyond it).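

In this assay, 4-methyl-3-oxopiperazin-1-yl in place of the group with two five-membered non-aromatic rings gives a 3.1-fold higher number from compound 3 to compound 4 (0.49 log units; beyond the scatter). This exchange of the two-ring group for a single six-membered non-aromatic ring with 2 hetero atoms clears the scatter, whereas the exchange with 2,6-dimethylmorpholin-4-yl does not, and it does so with the heavy-atom, donor and acceptor counts unchanged. Against the other single-ring groups the new group is not separated, with a 1.1-fold higher number from compound 2 to compound 4 (0.04 log units; within the scatter) and a 1.6-fold higher number from compound 1 to compound 4 (0.22 log units; within the scatter), and no measurement is available that would account for any of these steps.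

Compound 3 alone carries the two-ring group and its step to compound 1 lies within the scatter, so these compounds do not establish that the two-ring group stands apart from all the single-ring groups at this place on the shared core. Also open, from the compounds shown here alone, is how this place responds to a piperazin-2-one that keeps the amide hydrogen in place of the methyl, to a piperazine with a free ring amine, or to an open-chain dialkylamine.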